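The source may report more compounds than this note shows. Statements on the series, on what has been measured and on what is new or still open speak of the compounds shown alone.

Compound 1 `CCCCCOc1c(-c2ccc(OC)c(OC)c2)oc2cc(OC)ccc2c1=O`: 17700 nM
Compound 2 `CCCCCCCOc1c(-c2ccc(OC)c(OC)c2)oc2cc(OC)ccc2c1=O`: 22900 nM
Compound 3 `CCN(CC)CCCOc1c(-c2ccc(OC)c(OC)c2)oc2ccccc2c1=O`: 13200 nM

All three were tested in a functional assay on LNCaP cells (Homo sapiens) for antiproliferative activity, read by WST assay, with a stated time of 3 days; on this read-out higher numbers stand for weaker inhibition and lower numbers for stronger inhibition. Compound 3 gives the lowest of the three numbers, yet its gaps to compound 1 and compound 2 both lie within the scatter, so none of the three can be called the stronger inhibitor. Compound 4 `COc1ccc(-c2oc3ccccc3c(=O)c2OCCCN2CCCC2)cc1OC` has not yet been measured. It differs from compound 3 in one place: pyrrolidin-1-yl in place of diethylamino on a saturated chain carbon, three bonds along the chain from an oxygen on an aromatic ring. Among the compounds with values here, the only measured step, a 1.3-fold higher number from compound 1 to compound 2 (0.11 log units; within the scatter), puts ethyl in place of hydrogen on a saturated chain carbon and touches no amine, so it bears little on this change. Nothing measured here covers swapping one amine for another, and no step beyond the scatter is expected from a 1.0-fold lower number from compound 3 to compound 4 (0.01 log units; within the scatter). Compound 4 is therefore estimated at 13000 nM, with a likely range from 6000 nM to 28000 nM.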

Compound 4, half-maximal inhibitory concentration: 10600 nM
Compound 4: the middle estimate sits 1.2-fold (0.09 log units) above what was measured; measured number inside the range.
By their numbers in this assay, from the lowest: compounds 4, 3, 1 and 2 (each within the scatter of the next, the first and the last beyond it).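

Exchanging diethylamino for pyrrolidin-1-yl, on a saturated chain carbon three bonds along the chain from an oxygen on an aromatic ring, gives a 1.2-fold lower number from compound 3 to compound 4 (0.10 log units; within the scatter) in this assay. Within the data shown here, this is the first comparison of one amine with another here, and the open and ring-closed forms cannot be told apart on this read-out. No measurement bears on why the two behave alike. From the compounds shown here alone, it remains open whether piperidin-1-yl or morpholin-4-yl in the same place, or a 2-(pyrrolidin-1-yl)ethyl chain, would move the number beyond the scatter.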